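The source may report more compounds than this note shows. Statements on the series, on what has been measured and on what is new or still open speak of the compounds shown alone.

Measured in a functional assay on A549 cells (Homo sapiens) for antiproliferative activity, read by MTT assay, with a stated time of 72 h; on this read-out lower numbers stand for stronger inhibition and higher numbers for weaker inhibition:
- compound 1 `COc1cc(-c2ncnn2-c2ccc(Cl)cc2Cl)cc(OC)c1OC`: > 10000 nM (a limit)
- compound 2 `COc1cc(-c2ncnn2-c2ccc(N)cc2)cc(OC)c1OC`: > 10000 nM (a limit)
- compound 3 `COc1cc(-n2ncnc2-c2ccc(OC(F)(F)F)cc2)cc(OC)c1OC`: > 10000 nM (a limit)

None of the three compounds has a measured number. In this assay compound 3 gives > 10000 nM, which is a limit and not a number. Compound 4 `COc1cc(-n2ncnc2-c2ccc(OC(C)C)cc2)cc(OC)c1OC` differs from compound 3 in one group: isopropyl in place of trifluoromethyl on an oxygen on an aromatic ring. The change reads trifluoromethoxy to isopropoxy, with the rest of the structure untouched.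

For the measured compounds named here, only one measured step exists, a step that the two limits leave unreadable from compound 1 to compound 2. It concerns a different group, on an aromatic nitrogen, and offers no size to carry over. What remains is the limit of > 10000 nM in this assay, at which 3 of the 3 values shown sit. On that evidence, no step beyond the scatter is expected in this assay, and no direction can be assigned. The expected step is a number no higher from compound 3 to compound 4 (the limit leaves the size open). A report of compound 4 as another limit is the likeliest outcome. The estimate for compound 4 is 10000 nM, with an expected range from 3000 nM to 30000 nM.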

Compound 4, half-maximal inhibitory concentration: > 10000 nM
Compound 4: only a limit was reported; the forecaster's own chance of this, stated with the estimate: 75%; the middle value lies on the limit itself.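

In this assay compound 4 gives > 10000 nM as a limit and not a number. For the compounds shown here, compound 3 also gives only a limit, so no step between compound 3 and compound 4 can be read. The compounds shown leave open how strongly any of them inhibits, with no measured number among them: the limit of > 10000 nM in this assay, at which 4 of the 4 values shown sit.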